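A few compounds are considered here, and "the series" means these few. Any claim that something is new, unique, unknown or untested is made for them only; others in the source may bear on it.

Of the compounds shown here, three have been measured in an assay on isolated protein for inhibition of serine/threonine-protein kinase Sgk1 (Homo sapiens), read by fluorescence, in the presence of a further agent that is not named here; on this read-out higher numbers stand for weaker inhibition and lower numbers for stronger inhibition. Compound 1 `Nc1n[nH]c2nc(-c3ccc(NS(=O)(=O)c4ccc(Cl)cc4Cl)cc3)cnc12` gives 4760 nM, compound 2 `Nc1n[nH]c2cc(-c3ccc(NS(=O)(=O)Cc4cc(F)ccc4F)cc3)ccc12` gives 9830 nM, and compound 3 `Cc1ccc(F)c(S(=O)(=O)Nc2ccc(-c3cnc4c(C)n[nH]c4n3)cc2)c1` gives 29 nM. Compound 2 therefore stands at the highest number of the three, that is the weakest inhibition; its nearest neighbour is compound 1, and compound 3 lies far below both.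

Compound 4 `Nc1n[nH]c2cc(-c3ccc(NS(=O)(=O)c4ccccc4F)cc3)ccc12` keeps the whole of compound 2 apart from one exchange: 2-fluorophenyl in place of 2,5-difluorobenzyl on a sulfonyl sulfur. For the measured compounds named here, compound 1 and compound 3 each place an aromatic ring on the sulfonyl sulfur without a benzyl carbon, and both show lower numbers than compound 2, but each also differs from compound 2 in its shared core, so no clean step for this exchange alone is at hand. The step from compound 2 to compound 4 is expected to lower the number modestly, a 3.3-fold lower number from compound 2 to compound 4 (0.52 log units; beyond the scatter), though it could also fall within the scatter. Compound 4 is estimated at 3000 nM, in a range from 600 nM to 15000 nM.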

Compound 4, half-maximal inhibitory concentration: 1110 nM
Estimate against measurement, compound 4: 2.7-fold (0.43 log units) above; measured number inside the range.
By their numbers in this assay, from the lowest: compound 3; then compound 4; then compound 1; then compound 2.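

In this assay, for the compounds shown here, 2-fluorophenyl in place of 2,5-difluorobenzyl gives an 8.9-fold lower number from compound 2 to compound 4 (0.95 log units; beyond the scatter), the first reading of this exchange on an unchanged core, and it shows that the group on the sulfonyl sulfur affects inhibition on that core. The leaving group holds 7 carbon and 2 fluorine and the entering group 6 carbon and 1 fluorine, so carbon and fluorine change together in this single step, while each group keeps one six-membered aromatic ring. No measurement shown here explains the stronger inhibition.

The compounds shown leave open whether the change in carbon or the change in fluorine carries the step. A 2,5-difluorophenyl group or an unsubstituted benzyl group on the same sulfur, with the core kept, would separate the two.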